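The compounds below may be only part of what the source reports. "The series", "measured", "known", "first", "only" and "open" are said of these compounds alone.

Of the compounds shown here, two have so far been measured in a functional assay on HCT-116 cells (Homo sapiens) for antiproliferative activity, read by CCK-8 assay, with a stated time of 72 h, tested at 2 uM; a higher number here means a stronger effect of the compound at the concentration tested, a lower number a weaker effect. Compound 1 `CC(C)n1cnc2c(Nc3ccccc3)nc(NCOCc3ccc(/C=C/C(=O)Nc4ccccc4N)cc3)nc21` gives 2.53% in this assay, and compound 2 `CCCCn1cnc2c(Nc3ccccc3)nc(NCOCc3ccc(/C=C/C(=O)Nc4ccccc4N)cc3)nc21` gives 6.58%. Among the compounds with values here, the single step between them, a number 4.1 percentage points higher from compound 1 to compound 2 (within the scatter), is within the scatter, so compound 2 stands together with compound 1 in the same low range, with nothing in the numbers to separate the two. Compound 3 `Nc1ccccc1NC(=O)/C=C/c1ccc(COCNc2nc(Nc3ccccc3)c3ncn(C4CCCC4)c3n2)cc1` is the next member of the series and has not yet been measured. It differs from compound 2 by cyclopentyl in place of butyl on an aromatic nitrogen. Within the data shown here, the only measured step that bears on this change is the exchange of one group on that same aromatic nitrogen between compound 1 and compound 2, and that step stayed within the scatter. With two weak values and one uninformative step, there is no basis for expecting a step beyond the scatter in this assay, in either direction. Compound 3 is therefore estimated at 6%, with a range from -4% to 18%. The step this estimate means, a number 0.6 percentage points lower from compound 2 to compound 3 (within the scatter), is expected to lie within the scatter.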

Compound 3, a percentage reported as inhibition, at one concentration (the size of the read-out at that concentration, not a potency): 10.5%
Compound 3: the middle estimate sits 4.5 percentage points below what was measured; measured number inside the range.
By their numbers in this assay, from the lowest: compounds 1, 2 and 3 (each within the scatter of the next).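

In this assay, cyclopentyl brings a ring to this aromatic nitrogen for the first time among these compounds, and the step from the open butyl chain is a number 3.9 percentage points higher from compound 2 to compound 3 (within the scatter), while the comparison with isopropyl gives a number 8 percentage points higher from compound 1 to compound 3 (within the scatter). Isopropyl, butyl and cyclopentyl therefore all stand within the scatter of one another, so exchanging an open chain for a five-membered non-aromatic ring of carbon only has not separated these compounds at this position. Nothing available here offers an explanation for this result.

The compounds shown leave open whether any group on this nitrogen can produce a step beyond the scatter, for instance a benzyl group, a chain ending in an amine, or a carboxylic acid, since all three groups shown contain only carbon and hydrogen and none is aromatic. They also leave open whether the three compounds would differ in the strength of their effect at other concentrations, and whether a change elsewhere on the shared core would matter more than one at this nitrogen.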